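A few compounds are considered here, and "the series" means these few. Any claim that something is new, unique, unknown or untested is made for them only; others in the source may bear on it.

Of the compounds shown here, three built on a shared core have been tested in a functional assay on SW-620 cells (Homo sapiens) for antiproliferative activity, read by MTT assay, with a stated time of 72 h; on this read-out higher numbers stand for weaker inhibition and lower numbers for stronger inhibition. Compound 1, `COc1ccc(-c2cn(C/C=C3\OC(=O)C(OCc4ccccc4)=C3OCc3ccccc3)nn2)cc1`, sits at a limit of this assay, giving > 100000 nM rather than a number. Compound 3, `Cc1ccc(-c2cn(C/C=C3\OC(=O)C(OCc4ccccc4)=C3OCc3ccccc3)nn2)cc1`, likewise returns only a limit of > 100000 nM in this assay. The step that the two limits leave unreadable from compound 1 to compound 3 is therefore not readable. Compound 2, `O=C1O[C@H]([C@@H](O)Cn2cc(-c3cccc(O)c3)nn2)C(OCc2ccccc2)=C1OCc1ccccc1`, stands in the same place: in this assay compound 2 gives only the limit > 100000 nM and no number. All three values shown share (the limit of > 100000 nM in this assay, at which 3 of the 3 values shown sit).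

Compound 4, `O=C1O[C@H]([C@@H](O)Cn2cc(CNS(=O)(=O)c3ccc(F)cc3)nn2)C(OCc2ccccc2)=C1OCc1ccccc1`, differs from compound 2 in one place: (((4-fluorophenyl)sulfonyl)amino)methyl in place of 3-hydroxyphenyl on an aromatic carbon. Among the measured compounds shown here, no measured step bears directly on this change, and the one step recorded between two other compounds is unreadable because both of its ends sit at the limit of > 100000 nM in this assay, at which 3 of the 3 values shown sit. With nothing to read, no step beyond the scatter is expected in this assay in either direction, and compound 4 is most likely to return a limit once more. The expected step that the limit leaves unreadable from compound 2 to compound 4 is accordingly close to none. Compound 4 is estimated at 150000 nM in this assay, with a range from 50000 nM to 500000 nM.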

Compound 4, half-maximal inhibitory concentration: 41100 nM
The estimate for compound 4 lay 3.6-fold (0.56 log units) above the measured number, and the stated range ends above it.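

In this assay, putting (((4-fluorophenyl)sulfonyl)amino)methyl in place of 3-hydroxyphenyl, on this aromatic carbon of the five-membered aromatic ring with 3 nitrogen, gives an at least 2.4-fold lower number from compound 2 to compound 4 (0.38 log units; beyond the scatter), the first readable response to any change among these compounds. Compound 4 is the only one of the four to return a number, and the step can be given only as a minimum because compound 2 sits at a limit: the limit of > 100000 nM in this assay, at which 3 of the 4 values shown sit. The other step shown joins two limits and cannot be read, so this change is the only one here with a readable effect on activity.

Going by these compounds, the step covers the whole exchange of groups, so it remains open which part of the entering group carries it: the sulfonyl, the amino, the methyl link or the fluorine on the ring. On these data alone, it is also open whether a plain phenylsulfonyl group, an amide in place of the sulfonamide or a longer chain at this position would move the number further in either direction, and how far compound 4 could be improved from its still weak value.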